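Aryl variation on the shared core: compound 1 to compound 4

The source may report more compounds than this note shows. Statements on the series, on what has been measured and on what is new or still open speak of the compounds shown alone.

Three compounds of this series carry a measured value in an assay on CHO cells for displacement of a labelled ligand from adenosine receptor A1 (Homo sapiens), read by scintillation counting, with a stated time of 3 h; a lower number here means a stronger inhibitor, a higher number a weaker inhibitor. Compound 1 `Cn1c(-c2cccc(Cl)c2)nc2c(NC3CCCC3)ncnc21` gives 6.5 nM in this assay. Compound 2 `Cn1c(-c2ccccc2)nc2c(NC3CCC3)ncnc21` gives 3.2 nM, and compound 3 `CCCn1c(-c2ccccc2)nc2c(N)ncnc21` gives 101 nM. Among these three numbers compound 1 stands second highest: its nearest neighbour is compound 2, whose lower number lies beyond the usual scatter, and the furthest is compound 3, whose much higher number also lies beyond the scatter. Among the compounds with values here, no pair of measured compounds differs in only one place, so no single structural step can be read off directly from the data; compound 3 departs from the others in more than the aryl group alone.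

Compound 4 `Cc1ccc(-c2nc3c(NC4CCCC4)ncnc3n2C)cc1` is not yet measured. It differs from compound 1 in a single place: 4-methylphenyl in place of 3-chlorophenyl on an aromatic carbon. The aryl group keeps its size and its count of donors and acceptors, and only the substituent and its position on the ring change. With no measured step of this kind in the series, the expectation rests on the closeness of compound 1 and compound 2, which share the rest of the core and differ little in this assay. A step of modest size, if any, is expected, with a 1.5-fold higher number from compound 1 to compound 4 (0.19 log units; within the scatter) near or within the scatter and a slight lean towards a higher number. Compound 4 is estimated at 10 nM, with a range from 3 nM to 35 nM.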

Compound 4, inhibition constant: 8 nM
The estimate for compound 4 lay 1.3-fold (0.10 log units) above the measured number; the range from low to high includes it.
By their numbers in this assay, from the lowest: compound 2; then compounds 1 and 4 (each within the scatter of the next); then compound 3.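

In this assay, within the data shown here, the step of a 1.2-fold higher number from compound 1 to compound 4 (0.09 log units; within the scatter) is the first single-place comparison, and it lies within the scatter. At this aromatic carbon of the shared core, 4-methylphenyl therefore stands in place of 3-chlorophenyl with no difference that can be told from repeated measurement, although the substituent and its position on the ring both change at once. This holds for one pair only and, with compound 2 and compound 3 differing from these compounds in more than one place, it does not yet make a trend across the series; no measured data bear on why the two aryl groups read alike.

Because substituent and ring position change together in this step, the compounds shown do not separate the two, and 3-methylphenyl or 4-chlorophenyl on the same core would be needed to tell them apart. From the compounds shown here alone, how far this aromatic carbon accepts other kinds of group also remains open, for example a methoxy or a carboxylic acid on the phenyl ring, an aminomethyl substituent, or a pyridine ring in place of the phenyl.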